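Methoxy to formyl on the benzyl ring of compound 2

A few compounds are considered here, and "the series" means these few. Any claim that something is new, unique, unknown or untested is made for them only; others in the source may bear on it.

Measured so far:
- compound 1, `COc1cc(OCCOCCNC2CCCC2)ccc1OCc1ccccc1`, 44600 nM
- compound 2, `COc1ccc(COc2ccc(OCCOCCNC3CCCC3)cc2)cc1`, 15700 nM

In a functional assay on SK-OV-3 cells (Homo sapiens) for inhibition, read by CCK-8 assay, with a stated time of 70 h (a lower number here means a stronger inhibitor, a higher number a weaker inhibitor), compound 2 gives the lower of the two numbers; compound 1 gives a number that stands beyond the scatter above it. Compound 3, `O=Cc1ccc(COc2ccc(OCCOCCNC3CCCC3)cc2)cc1`, has not been measured. It differs from compound 2 by formyl in place of methoxy on an aromatic carbon. Among the measured compounds shown here, no step of this kind has been measured, so the direction is open; the expected step from compound 2 to compound 3 is a 1.0-fold higher number from compound 2 to compound 3 (0.01 log units; within the scatter), small and within the scatter. Compound 3 is therefore estimated at 16000 nM in this assay, with a range from 6000 nM to 45000 nM.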

Compound 3, half-maximal inhibitory concentration: 45000 nM
Beside the measured number, compound 3's estimate is 2.8-fold (0.45 log units) below it; the range from low to high includes it.
By their numbers in this assay, from the lowest: compound 2; then compounds 1 and 3 (each within the scatter of the next).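

In this assay, among the compounds shown here, the group on the benzyl ring is the only thing that changes here, and this first single-place step shows that it matters: formyl in place of methoxy gives a 2.9-fold higher number from compound 2 to compound 3 (0.46 log units; beyond the scatter) and stays beyond the scatter. On this one pair, the lower number goes with the 4-methoxybenzyl group, not the 4-formylbenzyl group. Nothing measured here bears on why the step occurs. As far as these compounds go, whether a hydroxymethyl group, a carboxylic acid or an amine on this aromatic carbon would give a lower or higher number remains open.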